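The source may report more compounds than this note shows. Statements on the series, on what has been measured and on what is new or still open speak of the compounds shown alone.

Three compounds sharing a common design were tested in a functional assay on PC-3 cells (Homo sapiens) for cytotoxicity, read by MTT assay, with a stated time of 72 h; on this read-out lower numbers stand for stronger inhibition and higher numbers for weaker inhibition. Compound 2 `Cc1cc(=O)n(-c2ccc(Br)cc2F)nc1C(=O)Nc1ccc(Oc2ncnc3[nH]ccc23)cc1` gives 2730 nM. Compound 1 `Cc1cc(=O)n(-c2cccc(F)c2)nc1C(=O)Nc1ccc(Oc2ncnc3[nH]ccc23)cc1` differs from it in a single spot, (3-fluorophenyl in place of 4-bromo-2-fluorophenyl on an aromatic nitrogen), and in this assay compound 1 gives 14600 nM. That one swap produced a 5.3-fold higher number from compound 2 to compound 1 (0.73 log units; beyond the scatter), a weakening of the effect on the cells. Compound 3 `Cc1cc(=O)n(-c2ccc(Br)cc2F)nc1C(=O)Nc1ccc(Oc2ncnc3c2ccn3C)c(F)c1` is built on a core that differs from that of compound 2; the difference between the two cores is not broken down here. In this assay compound 3 gives 6670 nM, a number sitting between those of the other two. Compound 4 `Cc1cc(=O)n(-c2cccc(F)c2)nc1C(=O)Nc1ccc(Oc2ncnc3c2ccn3C)c(F)c1` has not yet been measured. It stands to compound 3 exactly as compound 1 stands to compound 2: 3-fluorophenyl in place of 4-bromo-2-fluorophenyl on an aromatic nitrogen, at the same place in both pairs. The earlier pair showed that this change made a 5.3-fold higher number from compound 2 to compound 1 (0.73 log units; beyond the scatter). On that basis a step of matching size is expected for compound 4, namely a 4.5-fold higher number from compound 3 to compound 4 (0.65 log units; beyond the scatter). Compound 4 is therefore expected to give 30000 nM in this assay, with a plausible range from 12000 nM to 80000 nM.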

Compound 4, half-maximal inhibitory concentration: 8990 nM
Beside the measured number, compound 4's estimate is 3.3-fold (0.52 log units) above it, and the stated range ends above it.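

In this assay, putting 3-fluorophenyl in place of 4-bromo-2-fluorophenyl on the core of compound 3 gave a 1.3-fold higher number from compound 3 to compound 4 (0.13 log units; within the scatter), so this pair cannot be told apart here. The change therefore did not carry its effect from one core to the other, and its size depended on the core it was made on, at least for these two pairs: the same change on two cores in this assay, a 5.3-fold higher number (0.73 log units; beyond the scatter) from compound 2 to compound 1 and a 1.3-fold higher number (0.13 log units; within the scatter) from compound 3 to compound 4, 4.0-fold (0.60 log units) apart, beyond the scatter of two such steps This does not show which part of the difference between the cores matters, as that difference is not broken down, and two pairs give no rule for any further core.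

The compounds shown leave open how other groups on that aromatic nitrogen would behave on each core, such as a phenyl ring carrying an amine or a carboxylic acid, or a longer alkyl chain in place of the ring. They also leave open whether the two pairs would compare in the same way on other cell lines.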